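The source may hold more compounds than are shown below. What is called first, only, known or untested is meant among the compounds shown, and "the series" means these compounds.

Working notes on a small series read in an ADME assay on NCI-H460 cells (Homo sapiens) for cytotoxicity; a lower number here means a stronger inhibitor, a higher number a weaker inhibitor. Compound 1 (`Oc1cc(O)cc(CCCCCCCCCCCCCCc2cc(O)cc(O)c2)c1`) gives 28800 nM, compound 2 (`Oc1cc(O)cc(CCCCC/C=C/CCCCCCCc2cc(O)cc(O)c2)c1`) gives 27700 nM, and compound 3 (`Oc1cc2cc(c1)Oc1c(O)cc(cc1O)CCCCCCC/C=C/CCCCC2`) gives 28000 nM. Among the compounds with values here, these three values lie within the scatter of one another, so compound 2 stands level with the other two, and no step between measured compounds is available as a guide.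

Compound 4 (`COc1cc(O)cc(CCCCCCC/C=C/CCCCCc2cc(O)cc(O)c2)c1`) has not yet been measured. It differs from compound 2 by methyl in place of hydrogen on an oxygen on an aromatic ring, which reads as hydroxy to methoxy, or 3,5-dihydroxyphenyl to 3-hydroxy-5-methoxyphenyl. Within the data shown here, no measured compound carries a methoxy group, so the expectation rests only on the flat readings of compounds 1, 2 and 3. No shift beyond the scatter is expected in this assay, and no direction is favoured. The estimated 1.0-fold higher number from compound 2 to compound 4 (0.00 log units; within the scatter) is therefore small. Compound 4 is expected at 28000 nM, with an estimated range of 14000 nM to 55000 nM.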

Compound 4, half-maximal inhibitory concentration: 27000 nM
Compound 4: middle estimate off by 1.0-fold (0.02 log units), on the high side; the range from low to high includes it.
By their numbers in this assay, from the lowest: compounds 4, 2, 3 and 1 (each within the scatter of the next).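

In this assay, the first step available at this position reads a 1.0-fold lower number from compound 2 to compound 4 (0.01 log units; within the scatter) and so lies within the scatter. Methyl in place of hydrogen on an oxygen on an aromatic ring, read as 3,5-dihydroxyphenyl to 3-hydroxy-5-methoxyphenyl, therefore leaves the reading level, and this free hydroxy group is not needed to hold the number where compound 2 stands. Nothing available here explains why the reading stays level.

Still open, as far as these compounds go, is whether a larger group on this oxygen, such as ethyl or benzyl, or an amine or a carboxylic acid in place of the hydroxy group, would move the number beyond the scatter. Also open, from the compounds shown here alone, is whether methoxy on further oxygens of the shared core would leave the reading equally level.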